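A few compounds are considered here, and "the series" means these few. Any claim that something is new, unique, unknown or untested is made for them only; others in the source may bear on it.

Compound 3 `C/C(=C\CC/C(C)=C/CC[C@@H]1[C@@]2(C)CCC(=O)C(C)(C)[C@H]2CC[C@@]1(C)O)CC/C=C(\C)C(=O)OCc1cn(-c2ccc(C)cc2)nn1` carries the ester with a 1-(4-methylphenyl)-1H-1,2,3-triazol-4-yl group on the shared core. In a functional assay on A549 cells (Homo sapiens) for antiproliferative activity, read by MTT assay, with a stated time of 48 h (on this read-out higher numbers stand for weaker inhibition and lower numbers for stronger inhibition), compound 3 gives > 150000 nM, which is a limit of the assay and not a number. The two related compounds stand no differently. Compound 1 `C/C(=C\CC/C(C)=C/CC[C@@H]1[C@@]2(C)CCC(=O)C(C)(C)[C@H]2CC[C@@]1(C)O)CC/C=C(\C)C(=O)OCc1cn(-c2ccc([N+](=O)[O-])cc2)nn1` gives > 150000 nM in this assay, again a limit rather than a number. Compound 2 `C/C(=C\CC/C(C)=C/CC[C@@H]1[C@@]2(C)CCC(=O)C(C)(C)[C@H]2CC[C@@]1(C)O)CC/C=C(\C)C(=O)OCc1cn(-c2ccc(F)cc2)nn1` gives > 150000 nM in this assay, likewise a limit. Because all three values sit at the limit of > 150000 nM in this assay, at which 3 of the 3 values shown sit, the steps a step that the two limits leave unreadable from compound 1 to compound 2, a step that the two limits leave unreadable from compound 1 to compound 3 and a step that the two limits leave unreadable from compound 2 to compound 3 cannot be read in size or direction. Compound 4 `C/C(=C\CC/C(C)=C/CC[C@@H]1[C@@]2(C)CCC(=O)C(C)(C)[C@H]2CC[C@@]1(C)O)CC/C=C(\C)C(=O)OCc1cn(-c2cccc(C)c2)nn1` differs from compound 3 by 3-methylphenyl in place of 4-methylphenyl on an aromatic nitrogen. Among the measured compounds shown here, no measured step bears on this change, and the three values shown do not separate the aryl groups from one another. Compound 4 is therefore expected to show a number no higher from compound 3 to compound 4 (the limit leaves the size open), no step beyond the scatter. Compound 4 is estimated at 150000 nM, in a range from 80000 nM to 400000 nM, and most probably this assay will again report only a limit for it.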

Compound 4, half-maximal inhibitory concentration: > 150000 nM
Compound 4: only a limit was reported (the forecaster's own chance of this, stated with the estimate: 85%); the middle value lies on the limit itself.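

In this assay compound 4 gives > 150000 nM as a limit and not a number. Its steps from compound 1, compound 2 and compound 3 cannot be read in size or direction: the limit of > 150000 nM in this assay, at which 4 of the 4 values shown sit. The compounds shown leave open whether any aryl group on the shared core changes the activity.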